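Carbamoyl for Fluoro on a Shared Quinoline-Free Described Core

The compounds below may be only part of what the source reports. "The series", "measured", "known", "first", "only" and "open" are said of these compounds alone.

Measured compounds and their values in an assay on isolated protein with malate dehydrogenase, cytoplasmic (Sus scrofa) as the target; a higher number here means a weaker inhibitor, a lower number a stronger inhibitor:
compound 1, `CN(C)c1ccc2c(O)c(C(=O)O)cnc2c1`, 372000 nM;
compound 2, `NS(=O)(=O)c1ccc2c(O)c(C(=O)O)cnc2c1`, 692000 nM;
compound 3, `O=C(O)c1cnc2cc(F)ccc2c1O`, 11000000 nM.

Compound 3 carries the highest number of the three. Its nearest neighbour is compound 2, and the step of a 16-fold higher number from compound 2 to compound 3 (1.20 log units; beyond the scatter) is beyond the scatter; further away lies compound 1, with the step of a 30-fold higher number from compound 1 to compound 3 (1.47 log units; beyond the scatter). Between compound 1 and compound 2 the step of a 1.9-fold higher number from compound 1 to compound 2 (0.27 log units; within the scatter) stays within the scatter.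

Compound 4, `NC(=O)c1ccc2c(O)c(C(=O)O)cnc2c1`, has not yet been measured. It differs from compound 3 in one place: carbamoyl in place of fluoro on an aromatic carbon.

Going by the values given here, two measured steps bear on this change. Both exchanges at the same aromatic carbon, from dimethylamino or from sulfamoyl to fluoro, gave large increases in the number, as seen in a 30-fold higher number from compound 1 to compound 3 (1.47 log units; beyond the scatter) and a 16-fold higher number from compound 2 to compound 3 (1.20 log units; beyond the scatter). The reverse direction, fluoro to a group that again brings a hydrogen-bond donor and acceptor, is therefore expected to lower the number by a step of similar size, roughly a 16-fold lower number from compound 3 to compound 4 (1.20 log units; beyond the scatter).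

Compound 4 is accordingly estimated at 700000 nM in this assay, with a range from 250000 nM to 2500000 nM.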

Compound 4, half-maximal inhibitory concentration: 603000 nM
Estimate against measurement, compound 4: 1.2-fold (0.06 log units) above; the range from low to high includes it.
By their numbers in this assay, from the lowest: compounds 1, 4 and 2 (each within the scatter of the next); then compound 3.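

In this assay the carbamoyl group, with its 3 heavy atoms in place of the single fluorine, brings a large change at this aromatic carbon: an 18-fold lower number from compound 3 to compound 4 (1.26 log units; beyond the scatter). The new value also cannot be told apart from those of the two earlier groups, with a 1.1-fold lower number from compound 2 to compound 4 (0.06 log units; within the scatter) and a 1.6-fold higher number from compound 1 to compound 4 (0.21 log units; within the scatter), so dimethylamino, sulfamoyl and carbamoyl now form one level and compound 3, with fluoro, stands alone at a higher number. Nothing available here accounts for that gap or for the likeness of the three groups.

Going by these compounds, it remains open whether fluoro is unusual at this carbon or whether the level of the other three would also be reached by groups such as an amine, a methyl, a chlorine or a carboxylic acid, or by a longer chain on the amide nitrogen. All four compounds also keep the carboxylic acid and the hydroxyl of the shared core, so how the step from fluoro to carbamoyl behaves with either of those replaced, for example by an ester or a methoxy, cannot be judged from them.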